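The source may report more compounds than this note shows. Statements on the series, on what has been measured and on what is new or still open speak of the compounds shown alone.

Measured compounds:
compound 1, `COc1ccc(F)cc1CNCCCNc1ccnc2cc(Cc3cc(C)cc(C)c3)ccc12`: 9.47
compound 2, `Fc1ccc(Oc2ccc3c(NCCCNCc4ccco4)ccnc3c2)cc1`: 9.28
compound 3, `CCC(CC)c1ccc2c(NCCCNCc3cccc(OC)c3O)ccnc2c1`: 9.47

In a physicochemical assay for acid dissociation, compound 1 gives 9.47, the same number at the digits shown as compound 3, which gives 9.47; compound 2 gives 9.28, and all three numbers lie within the usual scatter of one another. Compound 4, `COc1ccc(F)cc1CNCCCNc1ccnc2cc(CCc3ccccc3)ccc12`, has not yet been measured in this assay. It differs from compound 1 in one place: benzyl in place of 3,5-dimethylphenyl on a saturated chain carbon bound to an aromatic carbon. Compound 2 and compound 3 vary from compound 1 in other places and still give numbers within the scatter, so nothing among the three points to a shift from such a change. The expected step is a number 0.02 log units lower from compound 1 to compound 4 (within the scatter), none beyond the scatter. Compound 4 is therefore expected to give 9.45 in this assay, estimated between 9.15 and 9.75.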

Compound 4, acid dissociation constant: 9.47
Compound 4: middle estimate off by 0.02 log units, on the low side; measured number inside the range.
By their numbers in this assay, from the lowest: compounds 2, 1, 3 and 4 (each within the scatter of the next).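

Among the compounds shown here, compound 1 and compound 4 form the only pair here that differs in one place, so they give the sole direct reading of this position in this assay. Benzyl in place of 3,5-dimethylphenyl on a saturated chain carbon bound to an aromatic carbon gives no change at the digits printed from compound 1 to compound 4 (within the scatter) and so leaves the read-out of the shared core unmoved for this exchange of one carbon-only aromatic group for another. No evidence on hand bears on this result. Going by these compounds, whether an amine or a carboxylic acid at this place would also leave the number unmoved stays open, as does the outcome with a longer chain.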